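Chain extension on the shared core: compound 1 to compound 4

This account rests on a few compounds, and the source may have more. Where it says the series, first, only, none or still open, it means among the compounds named here.

Among the measured compounds shown here, compound 1 `C=C1C(=O)S[C@H](CCCCCC)[C@H]1C(=O)O` gives 16700 nM in an assay for inhibition of fatty acid synthase (Rattus norvegicus) (on this read-out lower numbers stand for stronger inhibition and higher numbers for weaker inhibition), and stands highest of the three numbers measured so far. Compound 2 `C=C1C(=O)S[C@H](CCCCCCCCC)[C@H]1C(=O)O` gives 2280 nM in this assay, and compound 3 `C=C1C(=O)S[C@H](CCCCCCCCCC)[C@H]1C(=O)O` gives 1190 nM in this assay. The two chain extensions from compound 1 both lower the number: a 7.3-fold lower number from compound 1 to compound 2 (0.86 log units; beyond the scatter) and a 14-fold lower number from compound 1 to compound 3 (1.15 log units; beyond the scatter). The further single-carbon extension, a 1.9-fold lower number from compound 2 to compound 3 (0.28 log units; within the scatter), falls within the scatter.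

Compound 4 `C=C1C(=O)S[C@H](CCCCCCCCCCC)[C@H]1C(=O)O` differs from compound 1 by pentyl in place of hydrogen on a saturated chain carbon, six bonds along the chain from a saturated ring carbon. This carries the same chain one carbon beyond compound 3. The steps from compound 1 to compound 2 and from compound 1 to compound 3 bear directly on it and were modest to large; the step from compound 2 to compound 3 suggests the gain per added carbon is levelling off. A large drop in this assay is therefore expected, somewhat beyond that of compound 3. Compound 4 is expected to give 750 nM in this assay, within a range from 300 nM to 2000 nM. The expected step is a 22-fold lower number from compound 1 to compound 4 (1.35 log units; beyond the scatter).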

Compound 4, half-maximal inhibitory concentration: 790 nM
Estimate against measurement, compound 4: 1.1-fold (0.02 log units) below; measured number inside the range.
By their numbers in this assay, from the lowest: compounds 4, 3 and 2 (each within the scatter of the next, the first and the last beyond it); then compound 1.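

With the pentyl change at this position, the gain holds over the whole series in this assay, with a 21-fold lower number from compound 1 to compound 4 (1.33 log units; beyond the scatter) as the step on the shared core. The last single-carbon addition, a 1.5-fold lower number from compound 3 to compound 4 (0.18 log units; within the scatter), stays within the scatter, as did the one before it, yet the two additions taken together give a 2.9-fold lower number from compound 2 to compound 4 (0.46 log units; beyond the scatter) and so pass beyond it: the small steps add up, and the trend with chain length continues through compound 4 without a reversal. Nothing measured here gives a reason for this dependence on chain length.

Still open, from the compounds shown here alone, is whether a longer chain would lower the number again, level off or reverse the trend. Also open, going by these compounds, is whether a chain carrying an amine or a carboxylic acid would keep the gain seen with the plain alkyl chains.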